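The compounds below may be only part of what the source reports. "The series", "measured", "known", "first", "only" and "open" are said of these compounds alone.

Working notes on the series. The shared core is held constant; the compounds differ in the aryl group on the nitrogen on an aromatic ring. Compound 1 `Cc1ccc(Nc2nc(SCc3cn(CC(=O)NC(=O)Nc4ccccn4)nn3)nc(-c3ccc(C(C)C)cc3)c2C#N)cc1` carries 4-methylphenyl there, and in a functional assay on MGC-803 cells (Homo sapiens) for inhibition, read by MTT assay, with a stated time of 72 h (a higher number here means a weaker inhibitor, a lower number a stronger inhibitor), compound 1 gives 3360 nM. Compound 2 `Cc1ccccc1Nc1nc(SCc2cn(CC(=O)NC(=O)Nc3ccccn3)nn2)nc(-c2ccc(C(C)C)cc2)c1C#N` carries 2-methylphenyl, and in this assay compound 2 gives 19000 nM, the step being a 5.7-fold higher number from compound 1 to compound 2 (0.75 log units; beyond the scatter). Compound 3 `COc1ccccc1Nc1nc(SCc2cn(CC(=O)NC(=O)Nc3ccccn3)nn2)nc(-c2ccc(C(C)C)cc2)c1C#N` carries 2-methoxyphenyl. In this assay compound 3 reaches only a limit, > 64000 nM, so compound 3 has no number, only (the limit of > 64000 nM in this assay, at which 1 of the 3 values shown sits). The steps toward it read an at least 19-fold higher number from compound 1 to compound 3 (1.27 log units; beyond the scatter) and an at least 3.3-fold higher number from compound 2 to compound 3 (0.52 log units; beyond the scatter).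

Compound 4 `CC(C)c1ccc(Nc2nc(SCc3cn(CC(=O)NC(=O)Nc4ccccn4)nn3)nc(-c3ccc(C(C)C)cc3)c2C#N)cc1` is the next member: 4-isopropylphenyl in place of 2-methoxyphenyl on a nitrogen on an aromatic ring. The step from compound 1 to compound 3 bears most on this change, as it too sets 2-methoxyphenyl against 4-methylphenyl, an at least 19-fold higher number from compound 1 to compound 3 (1.27 log units; beyond the scatter); read in reverse it points to a large fall in number. The step of a 5.7-fold higher number from compound 1 to compound 2 (0.75 log units; beyond the scatter) points the same way. The expected step is therefore an at least 12-fold lower number from compound 3 to compound 4 (1.10 log units; beyond the scatter), a large fall in number. For compound 4 the estimate is 5000 nM, with a range from 1500 nM to 20000 nM.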

Compound 4, half-maximal inhibitory concentration: 15800 nM
For compound 4 the middle estimate is 3.2-fold (0.50 log units) below the measured one; the measured number falls inside the stated range.
By their numbers in this assay, from the lowest: compound 1; then compounds 4 and 2 (each within the scatter of the next). At a limit, above all of these: compound 3.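

Compound 1 keeps its lead: in this assay the change from methyl to isopropyl on the aromatic carbon gives a 4.7-fold higher number from compound 1 to compound 4 (0.67 log units; beyond the scatter) and so shows that the lower number seen with 4-methylphenyl does not carry over to 4-isopropylphenyl. The comparison with 2-methylphenyl gives a 1.2-fold lower number from compound 2 to compound 4 (0.08 log units; within the scatter) and leaves those two groups unseparated, so the earlier gap between compound 1 and compound 2 cannot be read as a general gap between the two placements of a carbon substituent. The step against 2-methoxyphenyl is an at least 4.0-fold lower number from compound 3 to compound 4 (0.60 log units; beyond the scatter) and its size is only a bound: the limit of > 64000 nM in this assay, at which 1 of the 4 values shown sits.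

As far as these compounds go, what a 4-methoxyphenyl group gives on the same nitrogen remains open, and with it whether the methoxy itself or its placement sets compound 3 apart. Also open, from the compounds shown here alone, is how an unsubstituted phenyl or a 4-fluorophenyl group would compare with 4-methylphenyl.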